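The compounds below may be only part of what the source reports. "The series", "measured", "known", "first", "only" and "open" are said of these compounds alone.

Compound 1 `CCCCN(CC)c1cc(C)nc2c1NC(=O)CN2c1ccc(C(C)C)cc1Br`: 0.7%
Compound 2 `CCCCN(CC)c1cc(C)nc2c1NC(=O)CN2c1ccc(C)cc1Cl`: "not determined" (no result reported)

In an assay on HEK-293T cells for displacement of a labelled ligand from corticotropin-releasing factor receptor 2 (Homo sapiens), read by scintillation counting, with a stated time of 2 h, tested at 1 uM (on this read-out higher numbers stand for more inhibition at the one concentration tested (going by the name of the read-out) and lower numbers for less inhibition), compound 1 gives 0.7%, while for compound 2 no result was reported, so compound 2 stands without a number. Compound 3 `CCCCN(CC)c1cc(C)nc2c1NC(=O)CN2c1ccc(OC)cc1C` differs from compound 2 by 4-methoxy-2-methylphenyl in place of 2-chloro-4-methylphenyl on a nitrogen on an aromatic ring in a ring. Within the data shown here, with no measured step to lean on, any shift in this assay from compound 2 to compound 3 is expected to stay within the usual scatter, in no particular direction. Resting on the low reading of compound 1, compound 3 is estimated at 5%, with a likely range from -10% to 25%.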

Compound 3, a percentage reported as inhibition, at one concentration (the size of the read-out at that concentration, not a potency): -2.3%
For compound 3 the middle estimate is 7.3 percentage points above the measured one; measured number inside the range.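

No step can be read from compound 2 to compound 3. These compounds leave open whether exchanging 2-chloro-4-methylphenyl for 4-methoxy-2-methylphenyl shifts inhibition at all. Nothing shown here bears on the low reading of compound 3.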